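The source may report more compounds than this note shows. Statements on the series, on what has been measured and on what is new or still open speak of the compounds shown alone.

Measured so far in an assay on HEK293 cells for inhibition of Steryl-sulfatase (Homo sapiens), tested at 1 uM; on this read-out lower numbers stand for a weaker effect and higher numbers for a stronger effect at the one concentration tested:

- compound 3, `CCCN(Cc1ccccc1)c1cccc(C(=O)N2CCc3ccc(OS(N)(=O)=O)cc3C2)c1`: 67.4%
- compound 2, `CN(C)CCCN(Cc1ccccc1)c1cccc(C(=O)N2CCc3ccc(OS(N)(=O)=O)cc3C2)c1`: 26%
- compound 1, `CCN(Cc1ccccn1)c1cccc(C(=O)N2CCc3ccc(OS(N)(=O)=O)cc3C2)c1`: 19.9%

Compound 3 stands highest of the three, and both of its neighbours lie well beyond the scatter below it. The two measured steps that lead to it are each large: a number 47.5 percentage points higher from compound 1 to compound 3 (beyond the scatter) and a number 41.4 percentage points higher from compound 2 to compound 3 (beyond the scatter). Both change only the group on the nitrogen attached to the aromatic ring, so this assay is clearly sensitive to what sits there.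

Compound 4, `CCN(Cc1ccccc1)c1cccc(C(=O)N2CCc3ccc(OS(N)(=O)=O)cc3C2)c1`, has not yet been measured. It differs from compound 3 by hydrogen in place of methyl on a saturated chain carbon, two bonds along the chain from a nitrogen on an aromatic ring. This is a smaller change than either measured step, and neither of them bears on it directly, because a number 47.5 percentage points higher from compound 1 to compound 3 (beyond the scatter) swaps the benzyl partner as well and a number 41.4 percentage points higher from compound 2 to compound 3 (beyond the scatter) removes a dimethylamino group rather than shortening the chain by one carbon. Within the data shown here, with no direct precedent, a modest loss is expected: for compound 4 the step of a number 12.4 percentage points lower from compound 3 to compound 4 (beyond the scatter) is estimated, giving an expected value of 55%, within a range from 30% to 78%.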

Compound 4, a percentage reported as inhibition, at one concentration (the size of the read-out at that concentration, not a potency): 69%
For compound 4 the middle estimate is 14 percentage points below the measured one, within the range that was stated.
By their numbers in this assay, from the lowest: compounds 1 and 2 (each within the scatter of the next); then compounds 3 and 4 (each within the scatter of the next).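

In this assay, going from propyl to ethyl on the nitrogen on an aromatic ring changes nothing that can be told from the scatter (a number 1.6 percentage points higher from compound 3 to compound 4 (within the scatter)), so this chain carbon can be removed without a visible effect on the read-out. With ethyl now held fixed, the change from pyridin-2-yl to phenyl can be read on its own, and it is large (a number 49.1 percentage points higher from compound 1 to compound 4 (beyond the scatter)), whereas the earlier comparison changed the chain length as well. Hydrogen in place of (dimethylamino)methyl also gives a large step (a number 43 percentage points higher from compound 2 to compound 4 (beyond the scatter)), so the ethyl and propyl compounds both stand well clear of the chain carrying dimethylamino.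

The compounds shown leave open whether a methyl or a butyl chain on this nitrogen, or a pyridin-3-yl ring in place of phenyl, would hold the number up. Nothing measured here explains why these changes act as they do.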